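The source may hold more compounds than are shown below. What is called first, only, known or untested is meant among the compounds shown, and "the series" means these compounds.

Compound 1 `COC(=O)Nc1cc(NC(=O)c2cccs2)cc(C(F)(F)F)c1` gives 2300 nM in an assay on HEK293-TREx cells for antagonist activity at transient receptor potential cation channel subfamily A member 1 (Homo sapiens), read by calcium flux; on this read-out higher numbers stand for weaker inhibition and lower numbers for stronger inhibition. Compound 2 `CCCNc1cc(NC(=O)c2ccccn2)cc(C(F)(F)F)c1` reaches only the assay limit of > 32000 nM in this assay, a limit rather than a number, and it therefore stands at the weak end of the numbers shown, as the limit of > 32000 nM in this assay, at which 1 of the 2 values shown sits, records. Compound 3 `CCCNc1cc(NC(=O)c2ccc(F)cc2)cc(C(F)(F)F)c1` carries 4-fluorophenyl in place of pyridin-2-yl on a carbonyl carbon. Among the measured compounds shown here, no measured step of this kind exists to lean on, so the direction of the change is open. Compound 3 is expected to give about 20000 nM in this assay, with a range of 5000 nM to 60000 nM. The expected step of an at least 1.6-fold lower number from compound 2 to compound 3 (0.20 log units; that floor lies within the scatter) is modest and may not exceed the scatter.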

Compound 3, half-maximal inhibitory concentration: 1400 nM
Compound 3: middle estimate off by 14-fold (1.15 log units), on the high side; measured number outside the range, below it.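

In this assay, the aromatic group on this carbonyl carbon proves to matter: 4-fluorophenyl in place of pyridin-2-yl gives an at least 22-fold lower number from compound 2 to compound 3 (1.35 log units; beyond the scatter). Among the compounds shown here, this is the first measured change at this place, and it turns a compound without a measurable number into one with a number. The true size of the step stays unknown because compound 2 is recorded only as a limit of the assay: the limit of > 32000 nM in this assay, at which 1 of the 3 values shown sits.

The change removes the ring nitrogen and adds fluorine in a single move, so the compounds shown cannot separate the two. A plain phenyl on the same carbonyl carbon would tell them apart.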